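Fluoro to trifluoromethoxy on compound 1: an expected step

The source may hold more compounds than are shown below. What is called first, only, known or untested is meant among the compounds shown, and "the series" means these compounds.

Among the measured compounds shown here, in a functional assay on MCF cells (Homo sapiens) for antiproliferative activity, with a stated time of 72 h (a higher number here means a weaker inhibitor, a lower number a stronger inhibitor), compound 1 `OC[C@H]1O[C@@H](n2cnc3c(NCc4ccc(F)cc4)ncnc32)[C@H](O)[C@@H]1O` gives 21000 nM, the only exact number so far. Compound 2 `OC[C@H]1O[C@@H](n2cnc3c(NCc4c(F)ccc(F)c4F)ncnc32)[C@H](O)[C@@H]1O` is reported only as a limit, > 166000 nM. Compound 1 is therefore the stronger of the two, and the measured step is an at least 7.9-fold higher number from compound 1 to compound 2 (0.89 log units; beyond the scatter).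

Compound 3 `OC[C@H]1O[C@@H](n2cnc3c(NCc4ccc(OC(F)(F)F)cc4)ncnc32)[C@H](O)[C@@H]1O` keeps the core of compound 1 and carries trifluoromethoxy in place of fluoro on an aromatic carbon, para to a large group (trifluoromethoxy in place of fluoro on an aromatic carbon). For the measured compounds named here, only one measured step bears on this change, and only loosely. That step, an at least 7.9-fold higher number from compound 1 to compound 2 (0.89 log units; beyond the scatter), replaces 4-fluorophenyl with 2,3,6-trifluorophenyl, so it alters the same aryl group but in a different way. It shows that a change on this group can shift the number in this assay, though it does not fix the size of a single replacement on compound 1. A small move towards a higher number is expected, far short of that seen for compound 2. The expected step is a 1.4-fold higher number from compound 1 to compound 3 (0.15 log units; within the scatter). For compound 3 the estimated value is 30000 nM, with an expected range of 10000 nM to 120000 nM.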

Compound 3, half-maximal inhibitory concentration: > 166000 nM
Compound 3 was reported as a limit (the forecaster's own chance of this, stated with the estimate: 20%); middle value at least 5.5-fold (0.74 log units) away from the limit.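

In this assay, trifluoromethoxy in place of fluoro on an aromatic carbon, para to a large group, proves to be a large change: the step is an at least 7.9-fold higher number from compound 1 to compound 3 (0.89 log units; beyond the scatter). Until now, only the replacement of 4-fluorophenyl by 2,3,6-trifluorophenyl had shown a step of this kind on the aryl group, and that change altered the ring at several carbons. Here, a single replacement at one aromatic carbon is enough to give a step beyond the scatter, although the step is only a minimum, and no order can be read between compound 2 and compound 3, which stand at the same limit: the limit of > 166000 nM in this assay, at which 2 of the 3 values shown sit.

Among the compounds shown here, compound 1, at 21000 nM, remains the only exact number, so the full size of neither step is known and the series has no exact value to show how the number changes with the group at this position. Going by these compounds, whether chloro, methoxy, a hydroxyl or an amine on the same aromatic carbon would stay close to compound 1 or also reach the limit remains open.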